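A few compounds are considered here, and "the series" means these few. Any claim that something is new, unique, unknown or untested is made for them only; others in the source may bear on it.

Compound 1 `COc1ccccc1C1=NN(C(=S)Nc2ccccc2)C(c2ccc3c(c2)OCCO3)C1` — 20300 nM
Compound 2 `S=C(Nc1ccccc1)N1N=C(c2cccc(Cl)c2)CC1c1ccc2c(c1)OCCO2` — > 200000 nM

In a functional assay on A-375 cells (Homo sapiens) for antiproliferative activity, read by MTT assay, with a stated time of 48 h (on this read-out lower numbers stand for stronger inhibition of growth and higher numbers for weaker inhibition of growth), compound 1 gives 20300 nM. For compound 2 this assay reports no number but only a limit, > 200000 nM; that limit is the limit of > 200000 nM in this assay, at which 1 of the 2 values shown sits. Among the measured compounds shown here, the single measured step is an at least 9.8-fold higher number from compound 1 to compound 2 (0.99 log units; beyond the scatter), and it exchanges one aryl group for another on the carbon that carries the double bond to nitrogen.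

Compound 3 `S=C(Nc1ccccc1)N1N=C(c2ccc(Cl)c(Cl)c2)CC1c1ccc2c(c1)OCCO2` keeps the whole of compound 2 and differs from it by chloro in place of hydrogen on an aromatic carbon. For the measured compounds named here, no measured step adds a chloro group to a ring already carrying one, so the step from compound 1 to compound 2 bears on it only indirectly: it shows that compound 2, with the 3-chlorophenyl group, already stands at the limit of this assay, and compound 3 starts from that limit. A change of this kind would have to move the number far to become visible.

Compound 3 is therefore expected to remain at or near the limit, with an estimated step of a number no higher from compound 2 to compound 3 (the limit leaves the size open). The estimate for compound 3 in this assay is 200000 nM, within a range from 60000 nM to 600000 nM.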

Compound 3, concentration for 50% growth inhibition: 41900 nM
Estimate against measurement, compound 3: 4.8-fold (0.68 log units) above; the whole stated range lies above it.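

In this assay the added chloro group, on the aromatic carbon ortho to a chloro group and para to a large group, gives an at least 4.7-fold lower number from compound 2 to compound 3 (0.67 log units; beyond the scatter), so substitution at this position does change the read-out, and the 3,4-dichlorophenyl group brings the number back from the limit into the measurable range. Set against the 2-methoxyphenyl group, the same 3,4-dichlorophenyl group still gives a 2.1-fold higher number from compound 1 to compound 3 (0.31 log units; beyond the scatter), so the loss seen with the 3-chlorophenyl group is only partly recovered, and the second chloro group does not carry compound 3 past compound 1. Compound 2 gives only a limit and not a number, so the true size of the gain stays unknown: the limit of > 200000 nM in this assay, at which 1 of the 3 values shown sits.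

The compounds shown leave open whether a chloro group at this position would act alone, without the chloro group already on the ring, and whether a fluoro, a methoxy or an amine in its place would give a similarly lower number. They also leave open whether the same addition would lower the number on the 2-methoxyphenyl ring of compound 1.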